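This account rests on a few compounds, and the source may have more. Where it says the series, first, only, none or still open, it means among the compounds named here.

Measured compounds in a functional assay on HeLa cells (Homo sapiens) for cytotoxicity, read by MTT assay, with a stated time of 48 h; on this read-out lower numbers stand for stronger inhibition and higher numbers for weaker inhibition:
- compound 1, `Cc1ccc(S(=O)(=O)/N=C(/CCNC2=CC(=O)c3ccccc3C2=O)Nc2cccc(C(F)(F)F)c2)cc1`: 77600 nM
- compound 2, `COc1ccc(N/C(CCNC2=CC(=O)c3ccccc3C2=O)=N\S(=O)(=O)c2ccc(C)cc2)cc1OC`: 14500 nM
- compound 3, `Cc1ccc(S(=O)(=O)/N=C(/CCNC2=CC(=O)c3ccccc3C2=O)Nc2ccc(F)c(F)c2)cc1`: 8790 nM

For the measured compounds named here, compound 3 gives the lowest of the three numbers in this assay, but its separation from compound 2 is within the scatter, so the two cannot be ordered; only the step of an 8.8-fold lower number from compound 1 to compound 3 (0.95 log units; beyond the scatter) stands clearly apart, as does a 5.4-fold lower number from compound 1 to compound 2 (0.73 log units; beyond the scatter).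

Compound 4, `COc1cc(N/C(CCNC2=CC(=O)c3ccccc3C2=O)=N\S(=O)(=O)c2ccc(C)cc2)cc(OC)c1OC`, has not been measured. It differs from compound 3 in one place: 3,4,5-trimethoxyphenyl in place of 3,4-difluorophenyl on an amine nitrogen.

The step that bears most directly on this change is a 1.6-fold lower number from compound 2 to compound 3 (0.22 log units; within the scatter), where two methoxy groups and two fluorines on the same ring gave numbers within the scatter of each other. Going by the values given here, no measured pair shows what a third methoxy group adds. On that basis the step from compound 3 to compound 4 is expected to stay within the scatter, a 1.4-fold higher number from compound 3 to compound 4 (0.14 log units; within the scatter), perhaps drifting toward the number of compound 2. For compound 4 the estimated value in this assay is 12000 nM, with a range from 5000 nM to 30000 nM.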

Compound 4, half-maximal inhibitory concentration: 3390 nM
For compound 4 the middle estimate is 3.5-fold (0.55 log units) above the measured one; measured number outside the range, below it.
By their numbers in this assay, from the lowest: compound 4; then compounds 3 and 2 (each within the scatter of the next); then compound 1.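

In this assay, for the compounds shown here, the group on the amine nitrogen still separates compounds when both carry methoxy groups: methoxy in place of hydrogen on an aromatic carbon gives a 4.3-fold lower number from compound 2 to compound 4 (0.63 log units; beyond the scatter) and is the only step here that shows what a third methoxy adds. The 3,4,5-trimethoxyphenyl group also stands apart from 3,4-difluorophenyl, with a 2.6-fold lower number from compound 3 to compound 4 (0.41 log units; beyond the scatter) as the step, and a 23-fold lower number from compound 1 to compound 4 (1.36 log units; beyond the scatter) is the widest step in the set at this position. No measurement at hand accounts for these differences.

As far as these compounds go, whether a hydroxy group or an amine in place of one methoxy would keep the number of compound 4 remains open. From the compounds shown here alone, all four compounds share the same core, so the effect of a change outside this aromatic group also remains open.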